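A few compounds are considered here, and "the series" means these few. Any claim that something is new, unique, unknown or untested is made for them only; others in the source may bear on it.

So far a physicochemical assay for solubility, in phosphate buffer, measured as kinetic solubility (a higher number here means a more soluble compound, a lower number a less soluble compound), has given numbers for two compounds. Compound 1 `CC(C)C(c1ccc(-c2ccc3cccc(F)c3c2)[nH]c1=O)C1NC(=O)NC1=O` gives 10600 nM, and compound 2 `CC(C)C(/C=C1\SC(=O)NC1=O)c1ccc(-c2ccc3cccc(F)c3c2)[nH]c1=O` gives 25600 nM, the higher of the two. Compound 3 `CC(C)C(c1ccc(-c2ccc3cccc(F)c3c2)[nH]c1=O)C1C(=O)NC(=O)N1C` has not been measured yet. It differs from compound 2 as follows: a group of 8 heavy atoms (4 carbon, 2 nitrogen, 2 oxygen; one five-membered non-aromatic ring with 2 hetero atoms) in place of a group of 8 heavy atoms (4 carbon, 1 nitrogen, 2 oxygen, 1 sulfur; one five-membered non-aromatic ring with 2 hetero atoms), on a saturated chain carbon bound to an aromatic carbon and a saturated chain carbon. The entering group is 3-methyl-2,5-dioxoimidazolidin-4-yl, and the rest of the molecule stays the same. Among the compounds with values here, only one measured step bears on this change: a 2.4-fold higher number from compound 1 to compound 2 (0.38 log units; beyond the scatter). That modest step replaced a group on the same saturated chain carbon with the group that now leaves. Within the data shown here, the entering group closely resembles the one in compound 1, so a modest step back down in this assay is expected, although a single step is thin evidence. The expected move is a 2.3-fold lower number from compound 2 to compound 3 (0.37 log units; beyond the scatter). For compound 3 the estimated value is 11000 nM, with an expected range from 4500 nM to 25000 nM.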

Compound 3, solubility: 17900 nM
Estimate against measurement, compound 3: 1.6-fold (0.21 log units) below; measured number inside the range.
By their numbers in this assay, from the lowest: compounds 1, 3 and 2 (each within the scatter of the next, the first and the last beyond it).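

In this assay, putting 3-methyl-2,5-dioxoimidazolidin-4-yl on this saturated chain carbon in place of the sulfur-containing ring gives a 1.4-fold lower number from compound 2 to compound 3 (0.16 log units; within the scatter), so this exchange cannot be told apart from the ordinary spread of repeat measurements. Adding a methyl in place of hydrogen on the amide-type nitrogen in the ring gives a 1.7-fold higher number from compound 1 to compound 3 (0.23 log units; within the scatter), which is also too small to read, even though the earlier step, a 2.4-fold higher number from compound 1 to compound 2 (0.38 log units; beyond the scatter), lies beyond the scatter. No measurement on hand offers a reason for these numbers.

As far as these compounds go, whether an ethyl group or a longer chain on that nitrogen would give a step beyond the scatter remains open. So does the outcome of placing an amine or a carboxylic acid on this ring.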